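Removing a Methyl From a Compound Inactive Against Trypsin

The source may hold more compounds than are shown below. What is called first, only, known or untested is meant among the compounds shown, and "the series" means these compounds.

Compound 1, `CS(=O)(=O)c1ccccc1-c1ccc(CC(=O)c2cc(C(F)(F)F)nn2-c2ccc3onc(N)c3c2)c(F)c1`, in an assay on isolated protein for inhibition of Trypsin (Homo sapiens) (on this read-out lower numbers stand for stronger inhibition and higher numbers for weaker inhibition), gives > 20000 nM, which is a limit of the assay.
Compound 2, `CC(C(=O)c1cc(C(F)(F)F)nn1-c1ccc2onc(N)c2c1)c1ccc(-c2ccccc2S(N)(=O)=O)cc1`, gives > 20000 nM, again a limit.
Compound 3, `CC(C(=O)c1cc(C(F)(F)F)nn1-c1ccc2onc(N)c2c1)c1ccc(-c2ccccc2S(C)(=O)=O)cc1`, gives > 20000 nM, also a limit.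

Compound 3 therefore stands at the limit of > 20000 nM in this assay, at which 3 of the 3 values shown sit, with no number of its own. Within the data shown here, the one step among the measured pairs, from compound 2 to compound 3, is a step that the two limits leave unreadable from compound 2 to compound 3, so it says nothing about size or direction. Compound 4, `CS(=O)(=O)c1ccccc1-c1ccc(CC(=O)c2cc(C(F)(F)F)nn2-c2ccc3onc(N)c3c2)cc1`, differs from compound 3 by hydrogen in place of methyl on a saturated chain carbon bound to an aromatic carbon and a carbonyl carbon. No measured step involves this change; compound 1 carries the same hydrogen at that carbon, but no step between compound 1 and compound 4 is shown, and compound 1 sits at the limit too. With every value shown sitting at the limit, no shift beyond the scatter is expected, and the step that the limit leaves unreadable from compound 3 to compound 4 is estimated as essentially none. Compound 4 is therefore expected to give 30000 nM in this assay, in the range 10000 nM to 100000 nM, most probably reported only as a limit.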

Compound 4, inhibition constant: > 20000 nM
Compound 4: a limit, no number; the forecaster's own chance of this, stated with the estimate: 90%; the middle value does not contradict the limit.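

No step can be read from compound 3 to compound 4 or from compound 1 to compound 4 in this assay, as each value is only a limit: the limit of > 20000 nM in this assay, at which 4 of the 4 values shown sit.
The compounds shown leave open whether either change alters inhibition at all, and how far any compound lies past that limit.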